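The source may report more compounds than this note shows. Statements on the series, on what has been measured and on what is new or still open speak of the compounds shown alone.

Compound 1 `CC(O)(CS(=O)(=O)c1cccc(OC(F)(F)F)c1)C(=O)Nc1ccc(S(F)(F)(F)(F)F)cc1` carries the 3-(trifluoromethoxy)phenyl on its sulfonyl sulfur, and in a functional assay on DU-145 cells (Homo sapiens) for antiproliferative activity, read by propidium iodide staining, with a stated time of 96 h (on this read-out lower numbers stand for stronger inhibition and higher numbers for weaker inhibition), compound 1 gives 26500 nM. Compound 2 `CC(O)(CS(=O)(=O)c1ccccc1OC(F)(F)F)C(=O)Nc1ccc(S(F)(F)(F)(F)F)cc1` differs from it in one place, (2-(trifluoromethoxy)phenyl in place of 3-(trifluoromethoxy)phenyl on a sulfonyl sulfur), and in this assay compound 2 gives 19500 nM, a step of a 1.4-fold lower number from compound 1 to compound 2 (0.13 log units; within the scatter). Compound 3 `CC(O)(CS(=O)(=O)c1cccc(OC(F)(F)F)c1)C(=O)Nc1cccc(S(F)(F)(F)(F)F)c1` rests on another core; the difference between the two cores is not broken down here. In this assay compound 3 gives 31500 nM. Compound 4 `CC(O)(CS(=O)(=O)c1ccccc1OC(F)(F)F)C(=O)Nc1cccc(S(F)(F)(F)(F)F)c1` is not yet measured and differs from compound 3 by 2-(trifluoromethoxy)phenyl in place of 3-(trifluoromethoxy)phenyl on a sulfonyl sulfur, the same change as before, occurring twice in all among these compounds. Because the earlier step of a 1.4-fold lower number from compound 1 to compound 2 (0.13 log units; within the scatter) stayed within the scatter, the expected step for compound 4 is a 1.4-fold lower number from compound 3 to compound 4 (0.15 log units; within the scatter). In this assay compound 4 is estimated at 22500 nM, expected between 12000 nM and 45000 nM.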

Compound 4, half-maximal inhibitory concentration: 29100 nM
Beside the measured number, compound 4's estimate is 1.3-fold (0.11 log units) below it, and the stated range covers the measured number.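

On the core of compound 3, 2-(trifluoromethoxy)phenyl in place of 3-(trifluoromethoxy)phenyl on a sulfonyl sulfur gives a 1.1-fold lower number from compound 3 to compound 4 (0.03 log units; within the scatter) in this assay. Set beside the same change on the other core, the two steps agree: the same change on two cores in this assay, a 1.4-fold lower number (0.13 log units; within the scatter) from compound 1 to compound 2 and a 1.1-fold lower number (0.03 log units; within the scatter) from compound 3 to compound 4, 1.3-fold (0.10 log units) apart, within the scatter of two such steps The change therefore carries over between these two cores, in that it stays within the scatter on both, but neither step stands clear of that scatter, so this does not show a real effect that transfers, and two cores make no general rule.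

From the compounds shown here alone, it remains open whether a phenyl carrying a nitrile or an amine on the sulfonyl sulfur would shift the numbers in this assay. Going by these compounds, it also remains open whether replacing the phenyl with a longer chain would do so.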